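Chloro for methoxy on a hydroxamic acid

The compounds below may be only part of what the source reports. "The series", "measured", "known", "first", "only" and "open" are said of these compounds alone.

Compound 1 `COc1cccc2ccc(CNCc3ccc(/C=C/C(=O)NO)cc3)nc12` gives 220 nM
Compound 2 `COc1ccc2nc(CNCc3ccc(/C=C/C(=O)NO)cc3)ccc2c1` gives 130 nM

In a functional assay on HEL cells (Homo sapiens) for antiproliferative activity, read by MTT assay, with a stated time of 48 h (a lower number here means a stronger inhibitor, a higher number a weaker inhibitor), compound 2 gives 130 nM and so lies within the usual scatter of compound 1 (220 nM). Compound 3 `O=C(/C=C/c1ccc(CNCc2ccc3cc(Cl)ccc3n2)cc1)NO` differs from compound 2 by chloro in place of methoxy on an aromatic carbon. Within the data shown here, no measured pair shows this change, so the expectation is only a cautious one. The expected step (a 1.2-fold higher number from compound 2 to compound 3 (0.06 log units; within the scatter)) is estimated to stay within the scatter, in neither direction. For compound 3 the estimated value in this assay is 150 nM within an expected range of 60 nM to 400 nM for repeated measurements.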

Compound 3, half-maximal inhibitory concentration: 220 nM
Compound 3: middle estimate off by 1.5-fold (0.17 log units), on the low side; the measured number falls inside the stated range.
By their numbers in this assay, from the lowest: compounds 2, 1 and 3 (each within the scatter of the next).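

Chloro in place of methoxy on this aromatic carbon gives a 1.7-fold higher number from compound 2 to compound 3 (0.23 log units; within the scatter) in this assay and is the only measured pair to show this change. In this pair, the methoxy group can therefore be exchanged for chloro at this position with no shift beyond the scatter. No available evidence bears on this result. On these data alone, whether an amine, a carboxylic acid or a plain hydrogen on this carbon would also stay within the scatter remains open. So does whether chloro would give the same result on other carbons of this ring.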